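A few compounds are considered here, and "the series" means these few. Any claim that something is new, unique, unknown or untested is made for them only; others in the source may bear on it.

Measured so far in an assay on CHO cells for displacement of a labelled ligand from prostaglandin E2 receptor EP3 subtype (Homo sapiens), read by radioligand binding; a lower number here means a stronger inhibitor, a higher number a weaker inhibitor:
compound 1 `CC(C)C(Nc1nccs1)c1ccc(-c2ccc3cccc(F)c3c2)[nH]c1=O` gives 9.4 nM
compound 2 `CC(C)C(c1ccc(-c2ccc3cccc(F)c3c2)[nH]c1=O)N1CCN/C1=N\C#N` gives 23 nM
compound 3 `CC(C)C(c1noc(=O)[nH]1)c1ccc(-c2ccc3cccc(F)c3c2)[nH]c1=O` gives 15 nM

Compound 3 sits second highest of the three numbers. For the measured compounds named here, its nearest neighbour is compound 2, the two lying within the scatter of each other, and the same holds for compound 1 and compound 3; the only step beyond the scatter is a 2.4-fold higher number from compound 1 to compound 2 (0.39 log units; beyond the scatter), a modest one.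

Compound 4 `CC(C)C(Cc1nnn[nH]1)c1ccc(-c2ccc3cccc(F)c3c2)[nH]c1=O` continues the exchange at the same position, the saturated chain carbon bound to an aromatic carbon and a saturated chain carbon. The change from compound 3 is a group of 6 heavy atoms (2 carbon, 4 nitrogen; one five-membered aromatic ring with 4 hetero atoms) in place of a group of 6 heavy atoms (2 carbon, 2 nitrogen, 2 oxygen; one five-membered aromatic ring with 3 hetero atoms), on a saturated chain carbon bound to an aromatic carbon and a saturated chain carbon.

Going by the values given here, the steps that bear on it are a 1.6-fold higher number from compound 1 to compound 3 (0.20 log units; within the scatter) and a 1.5-fold lower number from compound 2 to compound 3 (0.19 log units; within the scatter), both within the scatter, together with the modest 2.4-fold higher number from compound 1 to compound 2 (0.39 log units; beyond the scatter). All three groups tried at this position, differing in ring type and hetero atom count, leave the number in a narrow band. The (1H-tetrazol-5-yl)methyl group is of the same size as the group it replaces, so no step beyond the scatter is expected in this assay, in either direction.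

For compound 4 the estimate is 20 nM, with a range of 7 nM to 60 nM, which means an expected step of a 1.3-fold higher number from compound 3 to compound 4 (0.12 log units; within the scatter).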

Compound 4, inhibition constant: 34 nM
The estimate for compound 4 lay 1.7-fold (0.23 log units) below the measured number, within the range that was stated.
By their numbers in this assay, from the lowest: compounds 1, 3, 2 and 4 (each within the scatter of the next, the first and the last beyond it).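

In this assay, for the compounds shown here, the (1H-tetrazol-5-yl)methyl group gives the first step beyond the scatter from the ring of compound 3, a 2.3-fold higher number from compound 3 to compound 4 (0.36 log units; beyond the scatter), even though the entering and leaving groups have the same counts of heavy atoms, hydrogen-bond donors and hydrogen-bond acceptors, so those counts alone do not set the number at this saturated chain carbon. Going by these compounds alone, the step of a 1.5-fold higher number from compound 2 to compound 4 (0.17 log units; within the scatter) leaves compound 2 and compound 4 unresolved, while a 3.6-fold higher number from compound 1 to compound 4 (0.56 log units; beyond the scatter) is the widest step at this position so far, still only modest, so the position tolerates all four groups but does not treat them as equivalent. No measurement shown here accounts for the difference between the two rings of the same heavy atom count.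

The exchange from compound 3 to compound 4 alters the ring's hetero atoms and adds the methyl link together, so the shown compounds cannot assign the step to either change, and a 1H-tetrazol-5-yl group without the methyl would separate the two. On these data alone, whether a carboxylic acid or a simple amine at this carbon stays within the same modest span also remains open.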